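Aminotriazine coumarin ethers: anilino ring swap, dichloro to dimethyl

A few compounds are considered here, and "the series" means these few. Any claim that something is new, unique, unknown or untested is made for them only; others in the source may bear on it.

Compounds measured so far in an assay on COS-7 cells for agonist activity at Free fatty acid receptor 1 (Homo sapiens), read by scintillation counting and inositol phosphate accumulation, with a stated time of 90 min; on this read-out higher numbers stand for an effect only at larger amounts of compound and lower numbers for an effect already at smaller amounts:
compound 1 `Cc1ccc(Nc2nc(N)nc(COc3ccc4c(C)cc(=O)oc4c3)n2)cc1` gives 1790 nM
compound 2 `Cc1cc(=O)oc2cc(OCc3nc(N)nc(Nc4cccc(Cl)c4)n3)ccc12` gives 1110 nM
compound 3 `Cc1cc(=O)oc2cc(OCc3nc(N)nc(Nc4ccc(Cl)c(Cl)c4)n3)ccc12` gives 780 nM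

Compound 3 gives the lowest of the three numbers in this assay. Against compound 2 the step is a 1.4-fold lower number from compound 2 to compound 3 (0.15 log units; within the scatter), so the two cannot be ordered; against compound 1 the step is a 2.3-fold lower number from compound 1 to compound 3 (0.36 log units; beyond the scatter), a modest gap that does stand out. The step of a 1.6-fold lower number from compound 1 to compound 2 (0.21 log units; within the scatter) lies within the scatter as well.

Compound 4 `Cc1ccc(Nc2nc(N)nc(COc3ccc4c(C)cc(=O)oc4c3)n2)cc1C` differs from compound 3 in one place: 3,4-dimethylphenyl in place of 3,4-dichlorophenyl on a nitrogen on an aromatic ring. Going by the values given here, no measured pair isolates chloro against methyl on this ring. The closest guide is compound 1, where a single methyl on the phenyl ring gave the highest number of the set, and the step of a 2.3-fold lower number from compound 1 to compound 3 (0.36 log units; beyond the scatter) ran toward lower numbers on moving to the two chlorines. Reversing that in part, with methyl groups at both positions instead of chlorines, compound 4 is therefore expected to give a somewhat higher number than compound 3, in the region of compound 1, with a 1.8-fold higher number from compound 3 to compound 4 (0.25 log units; within the scatter) as the expected step. The estimate for compound 4 in this assay is 1400 nM, between 650 nM and 3000 nM; a step within the scatter remains possible.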

Compound 4, half-maximal effective concentration: 210 nM
The estimate for compound 4 lay 6.7-fold (0.82 log units) above the measured number; the whole stated range lies above it.
By their numbers in this assay, from the lowest: compound 4; then compounds 3, 2 and 1 (each within the scatter of the next, the first and the last beyond it).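

In this assay, going by these compounds alone, the direct swap of 3,4-dichlorophenyl for 3,4-dimethylphenyl on the nitrogen gives a 3.7-fold lower number from compound 3 to compound 4 (0.57 log units; beyond the scatter) and is the first comparison of chloro and methyl at this position, showing that the two substituted rings are not interchangeable here. The step of a 5.3-fold lower number from compound 2 to compound 4 (0.72 log units; beyond the scatter) extends this to the ring with one chlorine, and compound 4 stands apart from all three earlier compounds, with each of its steps beyond the scatter. The added methyl gives an 8.5-fold lower number from compound 1 to compound 4 (0.93 log units; beyond the scatter) whereas the added chlorine gives only a 1.4-fold lower number from compound 2 to compound 3 (0.15 log units; within the scatter) within the scatter, so compound 1 no longer supports reading a methyl on this ring as a route to higher numbers. No measurement at hand accounts for the difference between the methyl and chloro rings.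

Open, on these data alone, is whether ethyl or methoxy groups on the phenyl ring would track the methyl groups or the chlorines, and whether a ring carrying one chloro and one methyl would sit with compound 3 or compound 4. Also open, as far as these compounds go, is whether the same order would hold on any core other than the one shared by these four compounds.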